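The source may hold more compounds than are shown below. What is called first, only, known or untested is meant among the compounds shown, and "the series" means these compounds.

Of the compounds shown here, two built on one shared core have so far been measured in a physicochemical assay for solubility, read by HPLC, in phosphate buffer, at pH 6.5; a higher number here means a more soluble compound, a lower number a less soluble compound. Compound 1 `CNc1nc(NCCCN(C)C)c2sc(-c3ccc(-n4cccn4)cc3)cc2n1` carries one aromatic group on the five-membered ring that holds the sulfur; in this assay compound 1 gives 191 ug/mL. Compound 2 `CNc1nc(NCCCN(C)C)c2sc(-c3ccoc3)cc2n1` carries a furan-3-yl group at the same place; in this assay compound 2 gives 203 ug/mL. These two numbers sit within the scatter of each other, so the measurements so far do not separate compound 2 from compound 1 on this read-out.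

Compound 3 `CNc1nc(NCCCN(C)C)c2sc(-c3cncnc3)cc2n1` has not yet been measured. It differs from compound 2 in one place: pyrimidin-5-yl in place of furan-3-yl on an aromatic carbon, a pyrimidin-5-yl in place of a furan-3-yl on an aromatic carbon next to the ring sulfur. Among the measured compounds shown here, no measured pair here differs in only one place, so there is no measured step to lean on. In this assay the expected step is a 1.3-fold higher number from compound 2 to compound 3 (0.11 log units; within the scatter), a modest rise, though a result that stays within the scatter would not be surprising. Compound 3 is estimated at 260 ug/mL, with a range from 120 ug/mL to 550 ug/mL.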

Compound 3, solubility: 194 ug/mL
Estimate against measurement, compound 3: 1.3-fold (0.13 log units) above; measured number inside the range.
By their numbers in this assay, from the lowest: compounds 1, 3 and 2 (each within the scatter of the next).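

Among the compounds shown here, compounds 2 and 3 form the first measured pair that differs in only one place, an aromatic carbon next to the ring sulfur, so this position now has a step that can be read directly. In this assay, putting pyrimidin-5-yl in place of furan-3-yl gives a 1.0-fold lower number from compound 2 to compound 3 (0.02 log units; within the scatter) and so does not separate the two compounds. The swap replaces one five-membered aromatic ring with 1 hetero atom and 1 hydrogen-bond acceptor by one six-membered aromatic ring with 2 hetero atoms and 2 hydrogen-bond acceptors, yet this assay shows no difference beyond the scatter, and nothing measured here offers a reason for this.

All the groups shown at this position are aromatic rings, so it remains open whether a group of another kind there, such as an amine or a carboxylic acid, would give a number beyond the scatter of these. For the compounds shown here, it also remains open how this assay would respond to a change elsewhere on the shared core, such as a longer chain in place of the one carrying the dimethylamino group.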